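The compounds below may be only part of what the source reports. "The series", "measured", "known", "first", "only" and "open" are said of these compounds alone.

In a functional assay on PCO3 cells (Homo sapiens) for cytotoxicity, read by sulforhodamine B assay (a higher number here means a weaker inhibitor of growth, a lower number a stronger inhibitor of growth), compound 1 `CC1=CC[C@@H]([C@@](C)(O)CCCC(C)(C)NC(=S)NN)CC1` shows no number but only a limit of the assay, > 100000 nM. For the measured compounds named here, compound 2 `CC1=CC[C@@H]([C@@](C)(O)CCCC(C)(C)NC(=S)N/N=C\c2ccc(O)cc2)CC1` gives 13900 nM, so it holds the only true number so far, and that number lies in the micromolar range of the read-out. Going by the values given here, the single measured step, an at least 7.1-fold lower number from compound 1 to compound 2 (0.85 log units; beyond the scatter), attached the whole group that carries the aromatic ring to the end nitrogen. That step is large, but its size is bounded on one side by the limit, and it says nothing about substituents on the ring, since only one such substituent has been measured.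

Compound 3 `CC1=CC[C@@H]([C@@](C)(O)CCCC(C)(C)NC(=S)N/N=C\c2ccc([N+](=O)[O-])cc2)CC1` keeps the shared core and changes only the ring substituent: nitro in place of hydroxy on an aromatic carbon. This is nitro in place of hydroxy on an aromatic carbon, para to a large group, or 4-hydroxyphenyl to 4-nitrophenyl. Among the compounds with values here, with no measured step at this position, no firm direction can be argued in this assay, and a change of the size seen on adding the whole group is not expected. The expected step is modest, a 1.2-fold lower number from compound 2 to compound 3 (0.06 log units; within the scatter). For compound 3 the estimated value is 12000 nM, with an expected range from 4000 nM to 40000 nM.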

Compound 3, concentration for total growth inhibition: > 100000 nM
Compound 3 gave a limit, no number; the forecaster's own chance of this, stated with the estimate: 5%; middle value at least 8.3-fold (0.92 log units) from the limit.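

In this assay, the substituent on the aromatic carbon, para to a large group, proves to be a position that decides the read-out: nitro in place of hydroxy gives an at least 7.1-fold higher number from compound 2 to compound 3 (0.85 log units; beyond the scatter). The earlier step showed only what attaching the whole group with the aromatic ring did, whereas this one shows that keeping the ring is not enough to retain a measurable value, since compound 3, which still carries the ring, stands at a limit of the assay, > 100000 nM. As with the earlier step, the size of this change is bounded on one side only, and the true distance from compound 2 cannot be read: the limit of > 100000 nM in this assay, at which 2 of the 3 values shown sit.

Hydroxy and nitro are the only substituents shown at this position, so it remains open whether an amine, a methoxy group or a chlorine atom there would give a number near that of compound 2 or one at the limit. On these data alone, it is equally open whether a plain phenyl ring, with hydrogen in that place, would keep a measurable value in this assay.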